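The source may report more compounds than this note shows. Statements on the series, on what has been measured and on what is new or still open speak of the compounds shown alone.

Measured in a functional assay on MCF7 cells (Homo sapiens) for inhibition, read by resazurin assay, with a stated time of 24 h; on this read-out higher numbers stand for weaker inhibition and lower numbers for stronger inhibition:
- compound 1 `O=C1Nc2c(C(F)(F)F)cccc2C1(c1ccc(O)cc1)c1ccc(OC(F)(F)F)cc1`: 20 nM
- compound 2 `O=C1Nc2c(C(F)(F)F)cccc2C1(c1ccc(OC(F)(F)F)cc1)c1ccc(O)cc1F`: 177 nM
- compound 3 `O=C1Nc2c(C(F)(F)F)cccc2C1(c1ccc(OC(F)(F)F)cc1)c1ccc(OC(F)(F)F)cc1`: > 1000 nM

Compound 3 stands at the limit of > 1000 nM in this assay, at which 1 of the 3 values shown sits. That is only a limit of the assay, not a number.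

Compound 4 `O=C1Nc2c(C(F)(F)F)cccc2C1(c1ccc(OC(F)(F)F)cc1)c1ccc(O)c(O)c1` is compound 3 with one ring exchanged: 3,4-dihydroxyphenyl in place of 4-(trifluoromethoxy)phenyl on a saturated ring carbon. In words, 3,4-dihydroxyphenyl takes the place of 4-(trifluoromethoxy)phenyl on a saturated ring carbon.

Two measured steps lead up to compound 3 from compounds that keep a hydroxy-bearing ring: an at least 50-fold higher number from compound 1 to compound 3 (1.69 log units; beyond the scatter), and an at least 5.6-fold higher number from compound 2 to compound 3 (0.75 log units; beyond the scatter). Read in reverse, they point to a clearly lower number for compound 4 in this assay. How low is less certain. Compound 4 has a further group on its hydroxy-bearing ring, as compound 2 does, and adding fluoro there cost potency: an 8.9-fold higher number from compound 1 to compound 2 (0.95 log units; beyond the scatter). Compound 2, at 177 nM, is therefore the closest guide.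

The expected change is an at least 6.6-fold lower number from compound 3 to compound 4 (0.82 log units; beyond the scatter).

The estimate for compound 4 is 150 nM, with an expected range from 40 nM to 600 nM.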

Compound 4, half-maximal inhibitory concentration: 49 nM
Compound 4: middle estimate off by 3.1-fold (0.49 log units), on the high side; the measured number falls inside the stated range.
By their numbers in this assay, from the lowest: compound 1; then compound 4; then compound 2. At a limit, above all of these: compound 3.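

Compound 3 gives only a limit, not a number: the limit of > 1000 nM in this assay, at which 1 of the 4 values shown sits.

Even so, placing 3,4-dihydroxyphenyl in place of 4-(trifluoromethoxy)phenyl on the saturated ring carbon brings an at least 20-fold lower number from compound 3 to compound 4 (1.30 log units; beyond the scatter), and this ring also outperforms the fluoro-bearing ring, with a 3.6-fold lower number from compound 2 to compound 4 (0.56 log units; beyond the scatter). A second group on the hydroxy-bearing ring therefore need not cost the same in every case: the added hydroxy gives a 2.5-fold higher number from compound 1 to compound 4 (0.39 log units; beyond the scatter), a smaller loss than the fluoro's an 8.9-fold higher number from compound 1 to compound 2 (0.95 log units; beyond the scatter), while compound 1, with its single hydroxy, stays ahead of both.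

Fluoro and the added hydroxy sit at different places on the ring in compound 2 and compound 4, so the two groups have not been compared at one place. As far as these compounds go, how an amine or a carboxylic acid would fare on this ring remains open.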